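This account rests on a few compounds, and the source may have more. Where it says the series, first, only, none or still open, it means among the compounds named here.

In a functional assay with Homo sapiens as the target (on this read-out higher numbers stand for weaker inhibition and lower numbers for stronger inhibition), three compounds sharing one core have been measured. Compound 1 (`CC(C)[C@H](NC(=O)COc1cccc2ccccc12)C(=O)N[C@@H](CC(=O)O)C(=O)COC(=O)c1c(Cl)cccc1Cl`) gives 11500 nM and compound 2 (`CC(C)[C@H](NC(=O)COc1cccc2ccccc12)C(=O)N[C@@H](CC(=O)O)C(=O)COc1ccccc1`) gives 11200 nM on this read-out, while compound 3 (`CC(C)[C@H](NC(=O)COc1cccc2ccccc12)C(=O)N[C@@H](CC(=O)O)C(=O)COc1ccc(-c2ccccc2)cc1`) gives 38700 nM and stands highest of the three, which makes it the weakest inhibitor here. Compound 4 (`CC(C)[C@H](NC(=O)COc1cccc2ccccc12)C(=O)N[C@@H](CC(=O)O)C(=O)COc1ccccc1C(F)(F)F`) is still unmeasured. Its change from compound 3 is 2-(trifluoromethyl)phenyl in place of 4-phenylphenyl on an oxygen on a saturated carbon in one place, 2-(trifluoromethyl)phenyl in place of 4-phenylphenyl on an oxygen on a saturated carbon.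

The step that bears most directly is a 3.5-fold higher number from compound 2 to compound 3 (0.54 log units; beyond the scatter) (phenyl in place of hydrogen on an aromatic carbon), and a 3.4-fold higher number from compound 1 to compound 3 (0.53 log units; beyond the scatter) is about as large, whereas a 1.0-fold lower number from compound 1 to compound 2 (0.01 log units; within the scatter) shows no real change. Compound 4 keeps a single aromatic ring, like compound 2 at 11200 nM and unlike compound 3, so a modest step down is expected in this assay. Among the compounds with values here, no measured compound carries a trifluoromethyl group, so this expectation remains loose. The estimated change is a 2.8-fold lower number from compound 3 to compound 4 (0.44 log units; beyond the scatter) on this read-out. For compound 4 the estimate is 14000 nM with an expected range from 6000 nM to 32000 nM in repeat measurements.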

Compound 4, half-maximal inhibitory concentration: 17300 nM
Compound 4: middle estimate off by 1.2-fold (0.09 log units), on the low side, within the range that was stated.
By their numbers in this assay, from the lowest: compounds 2, 1 and 4 (each within the scatter of the next); then compound 3.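

In this assay, 2-(trifluoromethyl)phenyl in place of 4-phenylphenyl on this oxygen gives a 2.2-fold lower number from compound 3 to compound 4 (0.35 log units; beyond the scatter) and so moves the number back within the scatter of the other compounds. Trifluoromethyl in place of hydrogen on the phenyl ring gives a 1.5-fold higher number from compound 2 to compound 4 (0.19 log units; within the scatter) and 2-(trifluoromethyl)phenyl in place of (2,6-dichlorophenyl)carbonyl gives a 1.5-fold higher number from compound 1 to compound 4 (0.18 log units; within the scatter) and both steps stay within the scatter, so this position takes a trifluoromethyl group with no real change, and among the four compounds only the 4-phenylphenyl group of compound 3 stands apart. Nothing measured here explains these numbers.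

Still open, on these data alone, is whether a smaller group such as methoxy or a single chlorine on the phenyl ring would shift the number beyond the scatter. An amine on that ring is equally untested among the compounds shown.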